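This account rests on a few compounds, and the source may have more. Where it says the series, first, only, none or still open, it means among the compounds named here.

Working notes on the series. Compound 1 `Nc1ncn(CCC2(N)OC(=O)C(OCc3ccccc3)=C2OCc2ccccc2)c(=O)n1` is tested in a functional assay on SW-620 cells (Homo sapiens) for inhibition, read by MTT assay, with a stated time of 72 h (on this read-out lower numbers stand for stronger inhibition and higher numbers for weaker inhibition), and reaches only a limit of the assay, > 100000 nM. Compound 3 `Nc1ccn(C[C@H](O)[C@H]2OC(=O)C(OCc3ccccc3)=C2OCc2ccccc2)c(=O)n1` likewise returns only a limit in this assay, > 100000 nM. Going by the values given here, compound 2 `O=C1O/C(=C\Cn2ncc(=O)[nH]c2=O)C(OCc2ccccc2)=C1OCc1ccccc1`, the one member with a number in this assay, gives 36500 nM. Compound 1 therefore stands at the limit of > 100000 nM in this assay, at which 2 of the 3 values shown sit, with no measured number of its own, and the whole set sits at the weak end of the read-out.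

Compound 4 `NC1(CCn2ccc(=O)[nH]c2=O)OC(=O)C(OCc2ccccc2)=C1OCc1ccccc1` is the next entry. It differs from compound 1 by a group of 8 heavy atoms (4 carbon, 2 nitrogen, 2 oxygen; one six-membered aromatic ring with 2 hetero atoms) in place of a group of 8 heavy atoms (3 carbon, 4 nitrogen, 1 oxygen; one six-membered aromatic ring with 3 hetero atoms), on a saturated chain carbon, two bonds along the chain from a saturated ring carbon; the lactone with its two benzyloxy groups and the saturated chain are kept.

Among the compounds with values here, no step between measured compounds is available, so there is nothing to scale from. The expected step from compound 1 to compound 4 in this assay is a number no higher from compound 1 to compound 4 (the limit leaves the size open), that is, no movement beyond the scatter. The estimate for compound 4 in this assay is 100000 nM, between 30000 nM and 300000 nM, with a limit rather than a number the more likely outcome.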

Compound 4, half-maximal inhibitory concentration: > 100000 nM
Compound 4: only a limit was reported; the forecaster's own chance of this, stated with the estimate: 60%; the middle value sits exactly at the limit.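

Compound 1 and compound 4 both return only limits, so no step can be read between them: the limit of > 100000 nM in this assay, at which 3 of the 4 values shown sit. The compounds shown leave open whether the six-membered aromatic ring with 2 hetero atoms and the one with 3 hetero atoms differ at all in this assay.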